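Hexadecyl glycosylamide series: sulfate replaced by diol

A few compounds are considered here, and "the series" means these few. Any claim that something is new, unique, unknown or untested is made for them only; others in the source may bear on it.

Measured compounds:
compound 1 `CC(=O)N[C@H]1[C@@H](OCCCCc2ccccc2)O[C@H](CO)[C@@H](O)[C@@H]1O` — > 50 uM
compound 2 `C=CCCC(=O)N[C@H]1[C@@H](OCCCCCCCCCCCCCCCC)O[C@H](CO)[C@@H](O)[C@@H]1O` — > 50 uM
compound 3 `CCCCCCCCCCCCCCCCO[C@H]1O[C@H](COCC(CO)(CO)COS(=O)(=O)O)[C@@H](O)[C@H](O)[C@H]1NC(=O)CCCC` — 2.3 uM

In a functional assay on A-375 cells (Homo sapiens), read by thymidine incorporation (on this read-out lower numbers stand for stronger inhibition and higher numbers for weaker inhibition), compound 1 gives > 50 uM, which is a limit of the assay and not a number. Compound 2 likewise reaches only a limit in this assay, > 50 uM. Within the data shown here, compound 3 is the one compound with a measured number in this assay, 2.3 uM; the other two sit at the limit of > 50 uM in this assay, at which 2 of the 3 values shown sit. Among the measured compounds shown here, no two measured compounds differ in a single place, so no step can be read from these three.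

Compound 4 `CCCCCCCCCCCCCCCCO[C@H]1O[C@H](COC[C@H](O)CO)[C@@H](O)[C@H](O)[C@H]1NC(=O)CCCC` is not yet measured. It differs from compound 3 by 1,2-dihydroxyethyl in place of 2-hydroxy-1-(hydroxymethyl)-1-((sulfooxy)methyl)ethyl on a saturated chain carbon bound to an oxygen on a saturated carbon. The hexadecyl ether, the pentanoyl amide and the sugar core are kept, and the change is confined to the branched sulfated chain, which becomes a short diol.

For the measured compounds named here, no measured pair shows what this change does. The expectation is a loss of potency of modest size, possibly no further than the scatter, with the estimated step from compound 3 to compound 4 being a 2.6-fold higher number from compound 3 to compound 4 (0.42 log units; beyond the scatter). Compound 4 is estimated at 6 uM in this assay, expected between 1.5 uM and 25 uM.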

Compound 4, concentration for 50% inhibition: 2.2 uM
For compound 4 the middle estimate is 2.7-fold (0.44 log units) above the measured one; low and high end bracket the measured number.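

In this assay, putting 1,2-dihydroxyethyl in place of 2-hydroxy-1-(hydroxymethyl)-1-((sulfooxy)methyl)ethyl gives a 1.0-fold lower number from compound 3 to compound 4 (0.02 log units; within the scatter). The sulfate and the larger branch are therefore not required at this saturated chain carbon for a measured number in this series, and the short diol serves equally well here. Compound 4 stands with compound 3 as a measured value, and no step to the other two compounds can be read, since neither differs from it in one place: the limit of > 50 uM in this assay, at which 2 of the 4 values shown sit.

On these data alone, it remains open whether any oxygen is needed on this chain, which a plain propyl group, an amine or a carboxylic acid in place of 1,2-dihydroxyethyl would test. Also open, as far as these compounds go, is whether the defined stereocentre of 1,2-dihydroxyethyl matters in this assay.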